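Compound 4 Swaps Cyclopropyl for Methoxycyclobutyl on the Amide

A few compounds are considered here, and "the series" means these few. Any claim that something is new, unique, unknown or untested is made for them only; others in the source may bear on it.

Compound 1, `CCn1c(-c2cnc(C)nc2)nc2c(O[C@H]3CCN(C(=O)C4CC4)C3)ncnc21`, was examined in an ADME assay (Canis lupus familiaris, strain Beagle) for pharmacokinetics (on this read-out higher numbers stand for wider distribution into tissues and lower numbers for narrower distribution), where compound 1 gives 0.7 L/kg. Two other compounds were measured alongside it. Compound 2, `CCn1c(-c2cnc(C)nc2)nc2c(N[C@H]3CCN(C(=O)C4CCC4)C3)ncnc21`, gives 2.3 L/kg in this assay, and compound 3, `CCn1c(-c2ccc(C(F)(F)F)nc2)nc2c(O[C@H]3CCN(C(=O)c4cocn4)C3)ncnc21`, gives 3.4 L/kg. Compound 1 therefore stands lowest of the three; the gap to compound 2 and the larger gap to compound 3 both lie beyond the usual scatter. Among the measured compounds shown here, compound 2 and compound 3 each differ from compound 1 in more than one place, so no single change can be read off those gaps; they show only that the shared core can sit at either end of this span.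

Compound 4, `CCn1c(-c2cnc(C)nc2)nc2c(O[C@H]3CCN(C(=O)[C@H]4C[C@@H](OC)C4)C3)ncnc21`, has not yet been measured. It differs from compound 1 in one place: 3-methoxycyclobutyl in place of cyclopropyl on a carbonyl carbon. The cyclopropyl that leaves sits on a carbonyl carbon whose other neighbour is an amide-type nitrogen in a ring, and the 3-methoxycyclobutyl that enters brings one hydrogen-bond acceptor and two defined stereocentres where the cyclopropyl had none.

For the measured compounds named here, with no measured pair that isolates a change of this kind, the step is expected to be small: an estimated 1.1-fold higher number from compound 1 to compound 4 (0.06 log units; within the scatter), within the scatter. Compound 4 is therefore estimated at 0.8 L/kg, with a range from 0.4 L/kg to 1.6 L/kg.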

Compound 4, volume of distribution: 0.9 L/kg
Beside the measured number, compound 4's estimate is 1.1-fold (0.05 log units) below it, within the range that was stated.
By their numbers in this assay, from the lowest: compounds 1 and 4 (each within the scatter of the next); then compounds 2 and 3 (each within the scatter of the next).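

Among the compounds shown here, putting 3-methoxycyclobutyl in place of cyclopropyl on a carbonyl carbon gives a 1.3-fold higher number from compound 1 to compound 4 (0.11 log units; within the scatter), the first step in this assay that isolates a single change. The read-out therefore does not separate these two groups, even though the entering group brings a hydrogen-bond acceptor and two defined stereocentres that the cyclopropyl lacks, so at this position the exchange leaves the distribution indistinguishable from that of the starting compound within normal repeat variation. Nothing available here explains why the two groups read alike, so this stands as an observation without a known cause.

This single pair leaves open whether a group of a different kind on the same carbonyl carbon, such as an amine or a carboxylic acid, would move the read-out beyond the scatter. It also leaves open whether a plain cyclobutyl, a 3-hydroxycyclobutyl or the opposite arrangement of the two stereocentres would read the same way as the 3-methoxycyclobutyl does.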